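The compounds below may be only part of what the source reports. "The series", "measured", "known", "first", "only" and "open" are said of these compounds alone.

Of the compounds shown here, three have been measured in a functional assay on HepG2 cells (Homo sapiens) for cytotoxicity, read by MTT assay, with a stated time of 48 h; on this read-out lower numbers stand for stronger inhibition and higher numbers for weaker inhibition. Compound 1 `CCC(=O)N1N=C(C)CC1c1cc(Br)cc(Br)c1O` gives 41400 nM in this assay. Compound 2 `CC1=NN(S(=O)(=O)c2ccc([N+](=O)[O-])cc2)C(c2cc(Cl)ccc2O)C1` is recorded in this assay as "not active" (no number reported), with no number behind that entry. Compound 3 `Cc1ccc(C(=O)N2N=C(c3cc4ccccc4oc3=O)CC2c2ccccc2)cc1` gives 52300 nM in this assay, the higher of the two numbers available, yet its gap to compound 1 lies within the usual scatter of repeated measurements, so the two cannot be told apart on these data. No pair of these compounds differs in a single place, so no measured step exists to guide what follows.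

Compound 4 `CC(C)CNCC(=O)N1N=C(c2cc3ccccc3oc2=O)CC1c1ccccc1` differs from compound 3 in one place: (isobutylamino)methyl in place of 4-methylphenyl on a carbonyl carbon. Nothing measured here shows what that change does, so the expectation for compound 4 rests on compound 3 alone, whose 52300 nM already stands among weak numbers in this assay. The step is therefore estimated as a 1.1-fold higher number from compound 3 to compound 4 (0.02 log units; within the scatter), which amounts to no change beyond the scatter in either direction, with a real possibility that this assay again reports no number at all. Compound 4 is expected to give about 55000 nM in this assay, with a likely range from 25000 nM to 120000 nM.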

Compound 4, half-maximal inhibitory concentration: 9970 nM
Compound 4: the middle estimate sits 5.5-fold (0.74 log units) above what was measured; the whole stated range lies above it.
By their numbers in this assay, from the lowest: compound 4; then compounds 1 and 3 (each within the scatter of the next).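

In this assay, the group on this carbonyl carbon, whose other neighbour is an amide-type nitrogen in a ring, proves able to move the number: (isobutylamino)methyl in place of 4-methylphenyl gives a 5.2-fold lower number from compound 3 to compound 4 (0.72 log units; beyond the scatter), a step beyond the scatter and toward stronger inhibition. It also shows that, at least on this core, a six-membered aromatic ring of carbon only is not needed at this place for a measurable number, since the entering group has no ring and brings a nitrogen with one hydrogen-bond donor and one hydrogen-bond acceptor. No measured evidence bearing on the reason for this step is available.

A single step cannot separate the loss of the aromatic ring from the arrival of the nitrogen, since both happen in the same change. The compounds shown leave open what a pentyl chain with no nitrogen would give at this place, and whether a dimethylamino group or a carboxylic acid in place of the isobutylamino group would keep the lower number.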